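The source may hold more compounds than are shown below. What is called first, only, known or untested is meant among the compounds shown, and "the series" means these compounds.

Compound 1 `COc1cc(-c2ccnc3cc(-c4ccc(Cl)cc4)nn23)cc(OC)c1OC` is the starting point here. In a functional assay on B16-F0 cells (Mus musculus) for inhibition, read by CCK-8 assay, with a stated time of 48 h (a higher number here means a weaker inhibitor, a lower number a stronger inhibitor), compound 1 gives 4090 nM, the highest of the two numbers recorded among the compounds shown; the nearest is compound 3 `COc1cc(-c2ccnc3cc(-c4ccc5ccn(C)c5c4)nn23)cc(OC)c1OC`, which gives 657 nM in this assay. Compound 2 `COc1cc(-c2ccnc3c(-c4ccc(C)cc4)cnn23)cc(OC)c1OC` gives > 10000 nM in this assay, and this is a limit of the assay rather than a number, namely (the limit of > 10000 nM in this assay, at which 1 of the 3 values shown sits).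

The compound to be judged is compound 4 `COc1cc(-c2ccnc3cc(-c4ccc5cnn(C)c5c4)nn23)cc(OC)c1OC`. It differs from compound 1 in one place: 1-methyl-1H-indazol-6-yl in place of 4-chlorophenyl on an aromatic carbon.

Among the measured compounds shown here, only one measured step bears on this change. Going from compound 1 to compound 3, where 1-methyl-1H-indol-6-yl takes the place of 4-chlorophenyl on the same aromatic carbon, the number moved by a 6.2-fold lower number from compound 1 to compound 3 (0.79 log units; beyond the scatter). The group entering in compound 4, 1-methyl-1H-indazol-6-yl, is a close relative of that group, sharing the same fused arrangement of a five-membered and a six-membered ring and the methyl on ring nitrogen. A step of roughly that size, in the same direction, toward a lower number, is therefore expected for compound 4, namely a 4.5-fold lower number from compound 1 to compound 4 (0.66 log units; beyond the scatter).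

On this basis compound 4 is estimated to give 900 nM in this assay, with an expected range from 300 nM to 3000 nM.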

Compound 4, half-maximal inhibitory concentration: 1000 nM
The estimate for compound 4 lay 1.1-fold (0.05 log units) below the measured number, and the stated range covers the measured number.
By their numbers in this assay, from the lowest: compounds 3 and 4 (each within the scatter of the next); then compound 1. At a limit, above all of these: compound 2.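

In this assay, the move away from 4-chlorophenyl on this aromatic carbon of the five-membered ring now has a second example: a 4.1-fold lower number from compound 1 to compound 4 (0.61 log units; beyond the scatter). Together with compound 3, this shows that two different fused groups, each with a five-membered and a six-membered aromatic ring and a methyl on ring nitrogen, both give a step beyond the scatter in the same direction, so the earlier result no longer rests on a single group. Trading 1-methyl-1H-indol-6-yl for 1-methyl-1H-indazol-6-yl makes no readable difference, a 1.5-fold higher number from compound 3 to compound 4 (0.18 log units; within the scatter), although nothing measured here explains either this or the step away from 4-chlorophenyl.

Going by these compounds, what remains open is whether the methyl on ring nitrogen plays any part, a question that a plain 1H-indazol-6-yl group, with a hydrogen in its place, could answer. Also open, on these data alone, is what happens at this aromatic carbon with a group that has no fused ring at all, such as an amine or a carboxylic acid.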